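The compounds below may be only part of what the source reports. "The series", "measured", "known", "first", "only" and "open" are said of these compounds alone.

Series notes. Two pairs of esters share one change, tert-butyl in place of isobutyl on an oxygen next to a carbonyl group, on two different cores. Compound 1 `CC1=C(C(=O)OCC(C)C)C(c2ccsc2)NC(=S)N1` and compound 2 `CC1=C(C(=O)OC(C)(C)C)C(c2ccsc2)NC(=S)N1` carry one core; compound 3 `CC1=C(C(=O)OCC(C)C)C(c2ccco2)NC(=O)N1C` and compound 4 `CC1=C(C(=O)OC(C)(C)C)C(c2ccco2)NC(=O)N1C` carry the other. How the two cores differ is not broken down here.

In an assay on membranes from HeLa cells for displacement of a labelled ligand from adenosine receptor A3 (Homo sapiens), read by scintillation counting, with a stated time of 180 min, tested at 1 uM (on this read-out lower numbers stand for less inhibition and higher numbers for more inhibition at the one concentration tested (going by the name of the read-out)), compound 1 gives 2%. Compound 2 gives 16% in this assay, and the change tert-butyl in place of isobutyl on an oxygen next to a carbonyl group carries the step of a number 14 percentage points higher from compound 1 to compound 2 (beyond the scatter). Compound 3 gives 23% in this assay, which sits within the scatter of compound 2 and beyond the scatter of compound 1.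

Compound 4 differs from compound 3 by tert-butyl in place of isobutyl on an oxygen next to a carbonyl group, the same change as between the first pair. Going by the values given here, the expectation for compound 4 is a step of a number 12 percentage points higher from compound 3 to compound 4 (beyond the scatter) in this assay, resting on compound 2 because a number 14 percentage points higher from compound 1 to compound 2 (beyond the scatter) is the only measured instance of this change, and one instance on a different core is a thin base. Compound 4 is therefore estimated at 35% in this assay, with a range from 18% to 55%.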

Compound 4, a percentage reported as inhibition, at one concentration (the size of the read-out at that concentration, not a potency): 54%
Beside the measured number, compound 4's estimate is 19 percentage points below it, and the stated range covers the measured number.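

In this assay, tert-butyl in place of isobutyl on an oxygen next to a carbonyl group gives a number 31 percentage points higher from compound 3 to compound 4 (beyond the scatter), so the change points the same way on both cores, but its size does not carry over from one to the other: the same change on two cores in this assay, a number 14 percentage points higher (beyond the scatter) from compound 1 to compound 2 and a number 31 percentage points higher (beyond the scatter) from compound 3 to compound 4, 17 percentage points apart, beyond the scatter of two such steps

For this series, the direction of the step is therefore the only part that has held so far, and it rests on just two instances, which set no rule for a third core. How the two cores differ is not broken down, so these pairs do not show which part of a core goes with the larger step, and all of these numbers are readings at a single concentration, not potencies.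

Still open, on these data alone, is how a longer chain or a benzyl group on the same oxygen would read in this assay. Also open, as far as these compounds go, is whether a carboxylic acid or an amide in place of the ester would keep any of the displacement.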